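This account rests on a few compounds, and the source may have more. Where it says the series, first, only, none or still open, it means among the compounds named here.

Compound 1 `C[C@H](NC(=O)Nc1ccccc1C(C)(C)C)c1ccccc1` gives in an ADME assay on the whole organism with Oryza sativa as the target, tested at 0.1 uM (a lower number here means a stronger effect, a higher number a weaker effect of the compound at the concentration tested), a value of 101%, and compound 2 `C[C@H](NC(=O)Nc1ccccc1Cl)c1ccccc1` gives 99%. For the measured compounds named here, the step of a number 2 percentage points lower from compound 1 to compound 2 (within the scatter) therefore leaves the two compounds indistinguishable, so compound 2 stands level with its only neighbour rather than apart from it. Compound 3 `C[C@H](NC(=O)Nc1cc(Cl)ccc1Cl)c1ccccc1` differs from compound 2 by chloro in place of hydrogen on an aromatic carbon. Going by the values given here, the one measured step, a swap at the same ring, bore no change beyond the scatter, so no step beyond the scatter is expected here either, with no change at the digits printed from compound 2 to compound 3 (within the scatter) as the estimate. Compound 3 is thus expected to give about 99%, between 88% and 108%.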

Compound 3, a percentage reported as activity, at one concentration (the size of the read-out at that concentration, not a potency): 100%
Compound 3: middle estimate off by 1 percentage points, on the low side, within the range that was stated.
By their numbers in this assay, from the lowest: compounds 2, 3 and 1 (each within the scatter of the next).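

In this assay there is a number 1 percentage points higher from compound 2 to compound 3 (within the scatter) with the new chloro, which sits meta to a large group and para to a chloro group. The earlier step swapped one group for another at a single ring position, whereas this one adds a group at a second position and still leaves no readable difference. No available measurement bears on this result. From the compounds shown here alone, whether an amine or a carboxylic acid at this position would give a step beyond the scatter remains open.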